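Sulfonyl substituent exchange and maximal response in one agonist series

The compounds below may be only part of what the source reports. "The series", "measured", "known", "first", "only" and "open" are said of these compounds alone.

Compound 1 `Cc1ccc2[nH]c(C(=O)N[C@H]3CN(S(=O)(=O)c4cccnc4)C[C@@H]3C(=O)NCCN(C)C)cc2c1`, compound 2 `Cc1ccc2[nH]c(C(=O)N[C@H]3CN(S(=O)(=O)c4ccnnc4)C[C@@H]3C(=O)NCCN(C)C)cc2c1` and compound 3 `Cc1ccc2[nH]c(C(=O)N[C@H]3CCN(S(=O)(=O)c4ccccc4)C[C@@H]3C(=O)NCCN(C)C)cc2c1` share one core and differ at the sulfonyl substituent and elsewhere. In a functional assay on HEK293 cells for agonist activity at growth hormone secretagogue receptor type 1 (Homo sapiens), read by HTRF and inositol phosphate accumulation, with a stated time of 90 min, in the presence of a further agent that is not named here (on this read-out lower numbers stand for smaller maximal responses and higher numbers for larger maximal responses), compound 1 gives 90%, compound 2 gives 89% and compound 3 gives 98%. Compound 3 holds the highest of the three numbers, yet its gaps to compound 1 and compound 2 are within the scatter. Within the data shown here, the only single-point step measured so far is a number 1 percentage points lower from compound 1 to compound 2 (within the scatter). Compound 4 `Cc1ccc2[nH]c(C(=O)N[C@H]3CCN(S(=O)(=O)N4CCOCC4)C[C@@H]3C(=O)NCCN(C)C)cc2c1` follows from compound 3 by morpholin-4-yl in place of phenyl on a sulfonyl sulfur. Among the measured compounds shown here, no measured step trades an aromatic carbon ring for a non-aromatic hetero ring at this position, and the one sulfonyl swap on record stayed within the scatter. Compound 4 is therefore expected to show a number 4 percentage points lower from compound 3 to compound 4 (within the scatter) in this assay, nothing beyond the scatter. Compound 4 is estimated at 94%, between 80% and 105%.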

Compound 4, largest response reached (Emax), in percent of the reference or control that the assay uses: 98%
For compound 4 the middle estimate is 4 percentage points below the measured one; measured number inside the range.
By their numbers in this assay, from the lowest: compounds 2, 1, 3 and 4 (each within the scatter of the next).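

In this assay, the sulfonyl sulfur whose other neighbours are a sulfonamide nitrogen in a ring carries either an aromatic carbon ring or a non-aromatic ring with 2 hetero atoms, with no change at the digits printed from compound 3 to compound 4 (within the scatter). The earlier swap, a number 1 percentage points lower from compound 1 to compound 2 (within the scatter), involved two aromatic rings, so this step widens the range of groups compared at the position. No available data bear on the reason for this result.

Still open, on these data alone, is whether an acyclic diethylamino group or a chain ending in a carboxylic acid would give a comparable maximal response here. Potency at this position also remains open, as the maximal response does not address it.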